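Pyridine dicarbonitrile series: variation on the sulfur-linked chain

The source may report more compounds than this note shows. Statements on the series, on what has been measured and on what is new or still open speak of the compounds shown alone.

Measured so far in an assay on CHO cells for displacement of a labelled ligand from adenosine receptor A3 (Homo sapiens), read by scintillation counting, with a stated time of 120 min, tested at 1 uM; a higher number here means more inhibition at the concentration tested (going by the name of the read-out), a lower number less inhibition:
compound 1 `N#Cc1c(N)nc(SCn2cncn2)c(C#N)c1-c1ccc(OCC2CC2)cc1`, 1%
compound 2 `N#Cc1c(N)nc(SCC(N)=O)c(C#N)c1-c1ccc(OCC2CC2)cc1`, 8%
compound 3 `N#Cc1c(N)nc(SCc2cnc[nH]2)c(C#N)c1-c1ccc(OCC2CC2)cc1`, 1%

Compound 3 stands level with compound 1, the two together the lowest of the three numbers; the step is no change at the digits printed from compound 1 to compound 3 (within the scatter). Against compound 2 the step is a number 7 percentage points lower from compound 2 to compound 3 (within the scatter), so all three numbers sit within the scatter of one another in this assay, and none of the three compounds can be called weaker or stronger than another.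

Compound 4 `N#Cc1c(N)nc(SCC2=NCCN2)c(C#N)c1-c1ccc(OCC2CC2)cc1` is the next variation on the same position. The change is a group of 5 heavy atoms (3 carbon, 2 nitrogen; one five-membered non-aromatic ring with 2 hetero atoms) in place of a group of 5 heavy atoms (3 carbon, 2 nitrogen; one five-membered aromatic ring with 2 hetero atoms), on a saturated chain carbon bound to a sulfur.

The measured steps bearing on this are those at the same saturated chain carbon bound to a sulfur: a number 7 percentage points higher from compound 1 to compound 2 (within the scatter), no change at the digits printed from compound 1 to compound 3 (within the scatter) and a number 7 percentage points lower from compound 2 to compound 3 (within the scatter), every one within the scatter. Three different groups there have left the read-out in this assay unmoved, so no step beyond the scatter is expected in either direction for compound 4.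

Compound 4 is therefore expected to give about 3% in this assay, in the range 0% to 13%. The expected step is a number 2 percentage points higher from compound 3 to compound 4 (within the scatter).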

Compound 4, a percentage reported as inhibition, at one concentration (the size of the read-out at that concentration, not a potency): 6%
Estimate against measurement, compound 4: 3 percentage points below; the measured number falls inside the stated range.
By their numbers in this assay, from the lowest: compounds 1, 3, 4 and 2 (each within the scatter of the next).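

Replacing the aromatic 1H-imidazol-5-yl with the five-membered non-aromatic ring gives a number 5 percentage points higher from compound 3 to compound 4 (within the scatter) in this assay, so on this saturated chain carbon bound to a sulfur, aromaticity of the ring makes no difference that this read-out can show. The comparisons with the other two groups agree, with a number 2 percentage points lower from compound 2 to compound 4 (within the scatter) and a number 5 percentage points higher from compound 1 to compound 4 (within the scatter), which puts a fourth group within the scatter of the other three. No measurement shown here speaks to the reason for this.

From the compounds shown here alone, whether any group at this place can lift the read-out beyond the scatter remains open, for instance an amine, a carboxylic acid or a longer chain on the sulfur. Also open, going by these compounds, is whether changes elsewhere on the shared core, such as to the cyclopropylmethoxy group, would move this read-out.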